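A few compounds are considered here, and "the series" means these few. Any claim that something is new, unique, unknown or untested is made for them only; others in the source may bear on it.

Measured in an ADME assay on RAW264.7 cells (Mus musculus) for cytotoxicity, read by MTT assay, with a stated time of 24 h, in the absence of a further agent; a higher number here means a weaker inhibitor, a lower number a stronger inhibitor; each entry is a limit of the assay, not a number:
- Compound 1 `O=C1OC(Cc2nc(-c3ccc(Oc4ccccc4)cc3)no2)c2ccccc21`: > 40000 nM
- Compound 2 `COc1cc(OC)c2c(c1)C(C(O)c1ccc(O)cc1)OC2=O`: > 40000 nM
- Compound 3 `COc1ccc(C(O)C2OC(=O)c3c(OC)cc(OC)cc32)cc1`: > 40000 nM

Compound 3 stands only as a limit, with no number behind it. Among the measured compounds shown here, the other two compounds stand no differently, and the series so far is defined by the limit of > 40000 nM in this assay, at which 3 of the 3 values shown sit.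

Compound 4 `CCOc1ccc(C(O)C2OC(=O)c3c(OC)cc(OC)cc32)cc1` turns the methoxy of compound 3 into ethoxy: methyl in place of hydrogen on a saturated chain carbon bound to an oxygen on an aromatic ring. This is methyl in place of hydrogen on a saturated chain carbon bound to an oxygen on an aromatic ring.

The closest measured change is one bond further in, methyl in place of hydrogen on an oxygen on an aromatic ring. That step, a step that the two limits leave unreadable from compound 2 to compound 3, has no size that can be carried over.

No step beyond the scatter is expected in this assay, in either direction, because of the limit of > 40000 nM in this assay, at which 3 of the 3 values shown sit. The expected change is a step that the limit leaves unreadable from compound 3 to compound 4. For compound 4 the estimate is 50000 nM, with an expected range of 25000 nM to 100000 nM, and a report as a limit is the likeliest outcome.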

Compound 4, half-maximal inhibitory concentration: > 40000 nM
Compound 4 was reported as a limit; the forecaster's own chance of this, stated with the estimate: 85%; the middle value does not contradict the limit.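

Compound 4 gives > 40000 nM in this assay, a limit of the assay. Its steps from compound 2 and compound 3 cannot be read: the limit of > 40000 nM in this assay, at which 4 of the 4 values shown sit.

The compounds shown leave open whether methoxy to ethoxy has any size in this assay, and where any compound here would give a number.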